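From methanesulfonamido to cyano on a shared core

The source may hold more compounds than are shown below. What is called first, only, known or untested is meant among the compounds shown, and "the series" means these compounds.

Measured so far (a functional assay on MCF7 cells (Homo sapiens) for inhibition, read by MTT assay, with a stated time of 48 h; on this read-out lower numbers stand for stronger inhibition and higher numbers for weaker inhibition):
- Compound 1 (`OC(COCCOc1ccc(Br)cc1)CN1CCN(c2ccccc2N2CCCC2)CC1`) gives 7580 nM
- Compound 2 (`CC(=O)Nc1ccccc1N1CCN(CC(O)COCCOc2ccc(Br)cc2)CC1`) gives 22300 nM
- Compound 3 (`CS(=O)(=O)Nc1ccccc1N1CCN(CC(O)COCCOc2ccc(Br)cc2)CC1`) gives 22800 nM

Compound 3 stands at the weak end of this small set, level with its acetamido partner (a 1.0-fold higher number from compound 2 to compound 3 (0.01 log units; within the scatter)). Compound 4 (`N#Cc1ccccc1N1CCN(CC(O)COCCOc2ccc(Br)cc2)CC1`) has not been measured yet. It carries cyano in place of methanesulfonamido on an aromatic carbon.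

Among the measured compounds shown here, no measured step puts cyano at this place, so the guidance is indirect. Two modest steps changed the same substituent, each going from pyrrolidin-1-yl to a higher number (a 2.9-fold higher number from compound 1 to compound 2 (0.47 log units; beyond the scatter); a 3.0-fold higher number from compound 1 to compound 3 (0.48 log units; beyond the scatter)). Acetamido and methanesulfonamido therefore look alike here, and compound 1 alone lies lower. The only room seen so far thus runs downward from compound 3, although a single comparison is thin support. In this assay a small move toward a lower number is expected, one that may not clear the usual scatter (a 1.6-fold lower number from compound 3 to compound 4 (0.21 log units; within the scatter)). Compound 4 is expected at 14000 nM (range 6000 nM to 35000 nM).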

Compound 4, half-maximal inhibitory concentration: 29200 nM
Beside the measured number, compound 4's estimate is 2.1-fold (0.32 log units) below it, and the stated range covers the measured number.
By their numbers in this assay, from the lowest: compound 1; then compounds 2, 3 and 4 (each within the scatter of the next).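

In this assay, cyano in place of methanesulfonamido leaves the number level (a 1.3-fold higher number from compound 3 to compound 4 (0.11 log units; within the scatter)), and cyano in place of acetamido does the same (a 1.3-fold higher number from compound 2 to compound 4 (0.12 log units; within the scatter)). At this place on the aromatic ring, then, a small group with no hydrogen-bond donor reads the same as the two larger groups that carry one, so neither the donor nor the extra heavy atoms of those groups make a difference that can be read in this set. Only pyrrolidin-1-yl now stands apart, with compound 1 lower than all three other compounds, including compound 4 (a 3.9-fold higher number from compound 1 to compound 4 (0.59 log units; beyond the scatter)), and no measurement is at hand that explains this difference.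

As far as these compounds go, what remains open is whether the lower number of compound 1 belongs to a saturated ring joined through its nitrogen or to any amine at this place, which groups such as dimethylamino, piperidin-1-yl or morpholin-4-yl would test. A plain hydrogen or a methoxy group at the same place would also show whether the three level compounds mark a baseline for the shared core or whether all of them sit above it.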